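Methylating the carbamate nitrogen of a guanylate cyclase activator

This account rests on a few compounds, and the source may have more. Where it says the series, first, only, none or still open, it means among the compounds named here.

Measured compounds:
Compound 1, `COC(=O)N(C)c1c(N)nc(-c2nc(Cc3ccccc3F)n3ccccc23)nc1N`: 20400 nM
Compound 2, `CC1(C)C(=O)Nc2nc(-n3nc(Cc4c(F)ccc(F)c4F)c4cc(Cl)ccc43)nc(N)c21`: 7300 nM
Compound 3, `COC(=O)Nc1c(N)nc(-n2nc(Cc3c(F)ccc(F)c3F)c3cc(Cl)ccc32)nc1N`: 670 nM

Of the compounds shown here, three have been measured in an assay on CHO cells for activation of soluble guanylate cyclase alpha1/beta1 complex (Homo sapiens), read by cGMP accumulation; on this read-out higher numbers stand for an effect only at larger amounts of compound and lower numbers for an effect already at smaller amounts. Compound 3 holds the lowest number of the three, so it acts at the smallest amount. The nearest number belongs to compound 2, with 7300 nM, and that gap lies beyond the scatter; the furthest belongs to compound 1, with 20400 nM, again beyond the scatter. Compound 1 shares no single-point difference with the others, so its value says nothing by itself about the change considered here.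

Compound 4, `COC(=O)N(C)c1c(N)nc(-n2nc(Cc3c(F)ccc(F)c3F)c3cc(Cl)ccc32)nc1N`, has not yet been measured. It differs from compound 3 in one place: methyl in place of hydrogen on an amide-type nitrogen. Among the measured compounds shown here, no pair of measured compounds shows this change on its own, so its size cannot be read from the data. The expectation is that compound 4 stays close to compound 3, with a step of a 1.1-fold lower number from compound 3 to compound 4 (0.05 log units; within the scatter) that need not go beyond the scatter in either direction. Compound 4 is therefore estimated at 600 nM, within a range from 150 nM to 2500 nM.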

Compound 4, half-maximal effective concentration: 700 nM
Compound 4: middle estimate off by 1.2-fold (0.07 log units), on the low side; the range from low to high includes it.
By their numbers in this assay, from the lowest: compounds 3 and 4 (each within the scatter of the next); then compound 2; then compound 1.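

Putting methyl in place of the amide hydrogen, on the nitrogen whose other neighbours are an aromatic carbon and a carbonyl carbon, gives a 1.0-fold higher number from compound 3 to compound 4 (0.02 log units; within the scatter) in this assay and so stays inside the usual scatter. Among the compounds shown here, this is the first pair that isolates the change, which the earlier compounds could not do because none of them differed in this one place alone. For this pair, the amide hydrogen can be replaced by methyl with no difference that can be told apart from the scatter, so the hydrogen is not required for the effect seen here.

On these data alone, whether ethyl, benzyl or a longer chain on this same nitrogen would also leave the number within the scatter stays open, as does the outcome of the same swap on another core. Nothing available explains why methyl and hydrogen read alike here.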